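The source may hold more compounds than are shown below. What is called first, only, known or untested is meant among the compounds shown, and "the series" means these compounds.

For the measured compounds named here, in an ADME assay on HEp-2 cells (Homo sapiens) for cytotoxicity (on this read-out lower numbers stand for higher toxicity in this test and higher numbers for lower toxicity in this test), compound 2 `CC(C)CCn1c(Cn2c(=O)n(C(C)C)c3ccccc32)nc2cc(Br)ccc21` gives 18100 nM, the lower of the two numbers measured so far, and compound 1 `CC(C)CCn1c(Cn2c(=O)n(C(C)C)c3ccccc32)nc2cc(CF)ccc21` gives 37300 nM. Compound 3 `CCc1ccc2c(c1)nc(Cn1c(=O)n(C(C)C)c3ccccc31)n2CCC(C)C` keeps the shared core and differs from compound 2 in one group: ethyl in place of bromo on an aromatic carbon. Thus the bromo of compound 2 gives way to an ethyl group. Going by the values given here, only one measured step bears on this change, and it involves the same aromatic carbon, where bromo stands in place of fluoromethyl. That step is modest, at a 2.1-fold lower number from compound 1 to compound 2 (0.31 log units; beyond the scatter). Among the compounds with values here, no ethyl compound has been measured, and this single step does not show which way ethyl should move the number. A small change, not clearly beyond the scatter, is therefore expected, and the expected step is a 1.2-fold higher number from compound 2 to compound 3 (0.08 log units; within the scatter). For compound 3 the estimated value is 22000 nM, with an expected range of 11000 nM to 43000 nM.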

Compound 3, half-maximal cytotoxic concentration: 18500 nM
For compound 3 the middle estimate is 1.2-fold (0.08 log units) above the measured one; measured number inside the range.
By their numbers in this assay, from the lowest: compounds 2, 3 and 1 (each within the scatter of the next, the first and the last beyond it).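

In this assay, putting ethyl where bromo stood gives a 1.0-fold higher number from compound 2 to compound 3 (0.01 log units; within the scatter), so on this aromatic carbon the two groups cannot be told apart, even though one is a single bromine atom and the other a chain of two carbons. The second new step, methyl in place of fluoro on the chain carbon bound to the aromatic carbon, gives a 2.0-fold lower number from compound 1 to compound 3 (0.30 log units; within the scatter) and also stays within the scatter, which places ethyl within the scatter of both bromo and fluoromethyl, while those two remain beyond it from each other. Nothing available explains why these groups give such close numbers.

Going by these compounds, whether an amine, a carboxylic acid or a longer chain such as butyl on this aromatic carbon would give similar numbers stays open. So does whether changes elsewhere on the shared core would matter more.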